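The compounds below may be only part of what the source reports. "The series", "measured", "known", "first", "only" and "open" are said of these compounds alone.

For the measured compounds named here, compound 2, `Cc1cccc(-c2c(C)nn(-c3nc(-c4ccc(Cl)c(Cl)c4)c(SC(C)C)s3)c2C(=O)O)c1`, is one of two compounds measured in a functional assay on BJAB cells (Homo sapiens) for antiproliferative activity, with a stated time of 4 days; on this read-out higher numbers stand for an effect only at larger amounts of compound and lower numbers for an effect already at smaller amounts; compound 2 gives 17000 nM, the lowest of the two numbers. Compound 1, `Cc1nn(-c2nc(-c3ccc(Cl)c(Cl)c3)c(SC(C)C)s2)c(C(=O)O)c1-c1cncnc1`, gives 22000 nM in this assay, and the step of a 1.3-fold lower number from compound 1 to compound 2 (0.11 log units; within the scatter) lies within the scatter, so the two values are not distinguished from one another. Compound 3, `COc1ccc(C)cc1-c1c(C)nn(-c2nc(-c3ccc(Cl)c(Cl)c3)c(SC(C)C)s2)c1C(=O)O`, is not yet measured; it differs from compound 2 as follows: methoxy in place of hydrogen on an aromatic carbon. Going by the values given here, the only measured step that bears on this change is the one that altered the same part of the molecule, and it stayed within the scatter. Compound 3 is therefore expected to show a step of no change at the digits printed from compound 2 to compound 3 (within the scatter) in this assay, a move that does not exceed the scatter. The estimate for compound 3 in this assay is 17000 nM, with a range from 7000 nM to 40000 nM.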

Compound 3, half-maximal effective concentration: 9500 nM
Compound 3: middle estimate off by 1.8-fold (0.25 log units), on the high side; the range from low to high includes it.
By their numbers in this assay, from the lowest: compounds 3, 2 and 1 (each within the scatter of the next, the first and the last beyond it).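

In this assay, methoxy on the aromatic carbon ortho to a large group and para to a methyl group gives a 1.8-fold lower number from compound 2 to compound 3 (0.25 log units; within the scatter) so this change alone does not set compound 3 apart from compound 2. Replacing pyrimidin-5-yl with 2-methoxy-5-methylphenyl, however, gives a 2.3-fold lower number from compound 1 to compound 3 (0.36 log units; beyond the scatter) and this is a modest step, yet the first at this place to pass the scatter, which the step to the plain 3-methylphenyl did not do. No measurement at hand explains this result.

The compounds shown leave open whether an amine, a hydroxy group or a longer chain such as ethoxy at the same aromatic carbon would move the number further. They also leave open what an amide in place of the carboxylic acid would do, since all three compounds carry that acid.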